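The source may hold more compounds than are shown below. What is called first, only, known or untested is meant among the compounds shown, and "the series" means these compounds.

Measured so far in an assay on CHO cells for displacement of a labelled ligand from adenosine receptor A1 (Homo sapiens), read by radioligand binding; a lower number here means a stronger inhibitor, a higher number a weaker inhibitor:

Compound 1, `CCOc1cccc2cc(-c3ccc(OC)cc3)c(=O)oc12`: compound 1 gives > 100000 nM, a limit of the assay.
Compound 2, `CCOc1cccc2cc(-c3ccc([N+](=O)[O-])cc3)c(=O)oc12`: compound 2 gives > 100000 nM, also a limit.
Compound 3, `COc1cccc2cc(-c3ccc([N+](=O)[O-])cc3)c(=O)oc12`: compound 3 gives > 100000 nM, again a limit.

Compound 3 thus stands at the limit of this assay and not at a number. Going by the values given here, the same holds for the other two, so that the limit of > 100000 nM in this assay, at which 3 of the 3 values shown sit, describes the whole set and no compound can be ranked against another; no step between them has a readable size.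

Compound 4, `COc1ccc(-c2cc3cccc(OC)c3oc2=O)cc1`, differs from compound 3 by methoxy in place of nitro on an aromatic carbon. Among the compounds with values here, two measured steps bear on this exchange. The step that the two limits leave unreadable from compound 1 to compound 2 is the same exchange run the other way, on a core that carries ethoxy rather than methoxy. The step that the two limits leave unreadable from compound 2 to compound 3 alters the ether on the core while the nitro stays. Both steps begin and end at the limit, so neither gives a direction or a size to carry over. The present data offer no ground for expecting compound 4 to leave the limit.

For compound 4 in this assay the estimated value is 150000 nM, with an expected range from 50000 nM to 500000 nM. The step that the limit leaves unreadable from compound 3 to compound 4 is expected to stay within the scatter, and compound 4 is expected most probably to return only a limit as well.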

Compound 4, inhibition constant: > 100000 nM
Compound 4: only a limit was reported; the forecaster's own chance of this, stated with the estimate: 90%; the middle value is on the limit's open side.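

In this assay compound 4 gives > 100000 nM, again a limit and not a number. No size can be read for the steps to compound 4 from compound 3 or compound 1, and the whole set stays at one value: the limit of > 100000 nM in this assay, at which 4 of the 4 values shown sit.

The compounds shown leave open whether any exchange on the shared core would give a readable number in this assay.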